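Aryl thioether in place of dichlorophenoxy on the shared core

The compounds below may be only part of what the source reports. "The series", "measured", "known", "first", "only" and "open" are said of these compounds alone.

Compound 1 `Nc1cc(N)c2nc(-c3ccccc3)c(Oc3ccc(Cl)c(Cl)c3)nc2c1` has been tested in a functional assay on NCI-H226 cells (Homo sapiens) for inhibition, read by sulforhodamine B assay, with a stated time of 48 h; a lower number here means that less compound is tolerated, a higher number that more compound is tolerated. In this assay compound 1 gives only a limit, < 100000 nM. Compound 2 `COc1ccc(CNc2nc3cc(N)cc(N)c3nc2-c2ccccc2)cc1OC` gives a numerical value in this assay, 64600 nM. Compound 3 `CCOC(=O)[C@H](CCC(=O)O)NC(=O)c1ccc(Sc2nc3cc(N)cc(N)c3nc2-c2ccccc2)cc1` also stops at a limit in this assay, < 100000 nM. Within the data shown here, compound 1 therefore stands at the limit reached by two of the three results (the limit of < 100000 nM in this assay, at which 2 of the 3 values shown sit), and no measured step between compounds that differ in one place is available. Compound 4 `COc1ccc(Sc2nc3cc(N)cc(N)c3nc2-c2ccccc2)cc1` carries (4-methoxyphenyl)sulfanyl in place of 3,4-dichlorophenoxy on an aromatic carbon. The step that the limit leaves unreadable from compound 1 to compound 4 is expected to stay within the scatter. Compound 4 is expected at 60000 nM in this assay, between 20000 nM and 150000 nM.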

Compound 4, concentration lethal to 50% of the cells: < 100000 nM
Compound 4: only a limit was reported (the forecaster's own chance of this, stated with the estimate: 40%); the middle value does not contradict the limit.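

The step from compound 1 to compound 4 cannot be read, since both results are limits: the limit of < 100000 nM in this assay, at which 3 of the 4 values shown sit.

Going by these compounds, whether (4-methoxyphenyl)sulfanyl in place of 3,4-dichlorophenoxy changes the result in this assay stays open, with only compound 2 giving a numerical value.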